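Amide nitrogen substituent series: step to compound 4

A few compounds are considered here, and "the series" means these few. Any claim that something is new, unique, unknown or untested is made for them only; others in the source may bear on it.

compound 1 `COc1ccc2c(=O)c(/C=C/C(=O)Nc3cccc(Cl)c3)coc2c1` — > 100000 nM
compound 2 `COc1ccc2c(=O)c(/C=C/C(=O)Nc3ccc(Cl)cc3)coc2c1` — 37100 nM
compound 3 `COc1ccc2c(=O)c(/C=C/C(=O)NCc3ccc(C)cc3)coc2c1` — 14300 nM

The three measured compounds share one core and differ only in the group on the amide-type nitrogen. In a functional assay on Huh-7 cells (Homo sapiens) for inhibition, read by MTT assay, with a stated time of 48 h (a higher number here means a weaker inhibitor, a lower number a stronger inhibitor), compound 1 returns only a limit, > 100000 nM, which is not a number but the edge of what this assay reports (the limit of > 100000 nM in this assay, at which 1 of the 3 values shown sits). Compound 2 gives 37100 nM in this assay. Compound 3 gives 14300 nM in this assay. The steps: an at least 2.6-fold lower number from compound 1 to compound 2 (0.43 log units; beyond the scatter); an at least 6.9-fold lower number from compound 1 to compound 3 (0.84 log units; beyond the scatter); a 2.6-fold lower number from compound 2 to compound 3 (0.41 log units; beyond the scatter). Both changes away from compound 1 lead to lower numbers, the benzyl-type group of compound 3 the furthest.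

Compound 4 `COc1ccc2c(=O)c(/C=C/C(=O)NCc3ccccc3F)coc2c1` is not yet measured. It differs from compound 1 by 2-fluorobenzyl in place of 3-chlorophenyl on an amide-type nitrogen. Within the data shown here, the closest measured step is the one to compound 3, also a benzyl group on the amide-type nitrogen; it was at least modest and downward, as was the step to compound 2. A downward step of similar size is therefore expected, an at least 5.0-fold lower number from compound 1 to compound 4 (0.69 log units; beyond the scatter). Compound 4 is estimated at 20000 nM in this assay, expected between 6000 nM and 80000 nM.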

Compound 4, half-maximal inhibitory concentration: 8450 nM
For compound 4 the middle estimate is 2.4-fold (0.37 log units) above the measured one; measured number inside the range.
By their numbers in this assay, from the lowest: compounds 4 and 3 (each within the scatter of the next); then compound 2. At a limit, above all of these: compound 1.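

In this assay, among these compounds, the 2-fluorobenzyl group of compound 4 brings the only large step so far at this position on the amide-type nitrogen: an at least 11-fold lower number from compound 1 to compound 4 (1.07 log units; beyond the scatter). Compound 1 stands at a limit, so the size of that step is a bound only: the limit of > 100000 nM in this assay, at which 1 of the 4 values shown sits.

The two benzyl compounds do not separate, with a 1.7-fold lower number from compound 3 to compound 4 (0.23 log units; within the scatter), so 2-fluorobenzyl and 4-methylbenzyl read alike here, while the 4-chlorophenyl group of compound 2 remains clearly apart, with a 4.4-fold lower number from compound 2 to compound 4 (0.64 log units; beyond the scatter).

Open, from the compounds shown here alone, is how an unsubstituted benzyl group, a phenethyl chain or an aliphatic amine on this nitrogen would read in this assay. Also open, going by these compounds, is whether the fluorine and methyl substituents matter at all beyond the benzyl group itself.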